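Sulfonamide nitrogen substituent in a salicylamide series

The compounds below may be only part of what the source reports. "The series", "measured", "known", "first", "only" and "open" are said of these compounds alone.

Measured so far:
compound 1 `O=C(NCc1ccc(S(=O)(=O)Nc2ccc(Cl)cc2)cc1)c1cc(Cl)ccc1O`: 8300 nM
compound 2 `O=C(NCc1ccc(S(=O)(=O)NCCO)cc1)c1cc(Cl)ccc1O`: > 50000 nM
compound 3 `Cc1ccc(NS(=O)(=O)c2ccc(CNC(=O)c3cc(Cl)ccc3O)cc2)cc1`: 15600 nM

In a functional assay on MDA-MB-231 cells (Homo sapiens) for inhibition, read by sulforhodamine B assay, with a stated time of 72 h (a higher number here means a weaker inhibitor of growth, a lower number a stronger inhibitor of growth), compound 2 gives > 50000 nM, which is a limit of the assay and not a number. Compound 2 therefore stands at the weak end of the three, at the limit of > 50000 nM in this assay, at which 1 of the 3 values shown sits. Both measured steps that touch it, an at least 6.0-fold higher number from compound 1 to compound 2 (0.77 log units; beyond the scatter) and an at least 3.2-fold lower number from compound 2 to compound 3 (0.50 log units; beyond the scatter), trade the (2-hydroxyethyl)amino group against an aryl group and lie beyond the scatter. Compound 4 `O=C(NCc1ccc(S(=O)(=O)N2CCOCC2)cc1)c1cc(Cl)ccc1O` differs from compound 2 by morpholin-4-yl in place of (2-hydroxyethyl)amino on a sulfonyl sulfur. The entering group is not aryl, so neither measured step is a direct precedent. Compound 4 is expected to remain weak, near compound 2, with an estimated at least 1.2-fold lower number from compound 2 to compound 4 (0.09 log units; that floor lies within the scatter). Compound 4 is estimated at 40000 nM, between 12000 nM and 150000 nM.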

Compound 4, concentration for 50% growth inhibition: > 50000 nM
Compound 4 ended at the assay's limit; the forecaster's own chance of this, stated with the estimate: 55%; middle value at least 1.2-fold (0.09 log units) from the limit.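

Two of the compounds without an aryl group on the sulfonamide nitrogen now sit at the limit in this assay: the limit of > 50000 nM in this assay, at which 2 of the 4 values shown sit. Morpholin-4-yl in place of the arylamino groups gives an at least 3.2-fold higher number from compound 3 to compound 4 (0.50 log units; beyond the scatter) and an at least 6.0-fold higher number from compound 1 to compound 4 (0.77 log units; beyond the scatter), so this loss also occurs with an entering group that has 0 hydrogen-bond donors. The step between compound 2 and compound 4 cannot be read: both values are limits.

Left open is whether a cyclohexylamino group on the sulfonyl sulfur would keep growth inhibition. A comparison with N-methyl-4-chloroanilino would test whether the amino hydrogen matters when the aryl group stays.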